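The source may hold more compounds than are shown below. What is called first, only, known or untested is meant among the compounds shown, and "the series" means these compounds.

Two measured compounds share one core. Compound 1 `CC(C)c1coc(-c2cccc(CNc3ccc4[nH]nc(C(=O)O)c4c3)c2O)n1` carries a 4-isopropyl-1,3-oxazol-2-yl group, and in an assay on isolated protein for inhibition of 2-Hydroxyacid oxidase 1 (Homo sapiens), with stated times of 30 min and 15 min (a higher number here means a weaker inhibitor, a lower number a stronger inhibitor), compound 1 gives 87 nM. Compound 2 `Cc1csc(-c2cccc(CNc3ccc4[nH]nc(C(=O)O)c4c3)c2O)n1` carries a 4-methyl-1,3-thiazol-2-yl group instead, and in this assay compound 2 gives 23 nM. That is a 3.8-fold lower number from compound 1 to compound 2 (0.58 log units; beyond the scatter). Among the compounds with values here, compound 2 thus stands at the lowest of the two numbers, with compound 1 as its only neighbour. Compound 3 `CC(C)c1csc(-c2cccc(CNc3ccc4[nH]nc(C(=O)O)c4c3)c2O)n1` is not yet measured; it differs from compound 2 by isopropyl in place of methyl on an aromatic carbon. Within the data shown here, only one measured step bears on this change, and only in part: the step from compound 1 to compound 2 traded the ring and its group at once, so it cannot tell how much of its size came from methyl replacing isopropyl and how much from the 1,3-thiazol-2-yl ring replacing the 1,3-oxazol-2-yl ring. Compound 3 is therefore expected to sit near compound 2, with a small rise as a 2.0-fold higher number from compound 2 to compound 3 (0.29 log units; within the scatter), giving an estimate of 45 nM within a range of 15 nM to 130 nM.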

Compound 3, half-maximal inhibitory concentration: 65 nM
Compound 3: the middle estimate sits 1.4-fold (0.16 log units) below what was measured; measured number inside the range.
By their numbers in this assay, from the lowest: compound 2; then compounds 3 and 1 (each within the scatter of the next).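

Compound 3 separates the two changes that were mixed in the earlier step. In this assay, isopropyl in place of methyl on an aromatic carbon next to the ring nitrogen, with the 1,3-thiazol-2-yl ring kept, gives a 2.8-fold higher number from compound 2 to compound 3 (0.45 log units; beyond the scatter), so this small change at this position alone moves the number beyond the scatter. With isopropyl kept instead, the 1,3-thiazol-2-yl ring in place of the 1,3-oxazol-2-yl ring gives a 1.3-fold lower number from compound 1 to compound 3 (0.13 log units; within the scatter), so among these three compounds the ring swap shows no difference that can be told from the scatter, and the earlier step tracks mainly the change from isopropyl to methyl, though nothing measured here explains why.

From the compounds shown here alone, with only methyl and isopropyl at this position, it remains open whether an ethyl group would fall between them, and what a bare hydrogen or a methoxy group would give. Going by these compounds, it also remains open whether the ring swap would stay as quiet with methyl on the ring, a question that the 4-methyl-1,3-oxazol-2-yl group could settle.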